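Swapping Nitro for Bromo: What to Expect of Compound 4

The source may hold more compounds than are shown below. What is called first, only, known or untested is meant among the compounds shown, and "the series" means these compounds.

Of the compounds shown here, three have so far been tested in a functional assay on PANC-1 cells (Homo sapiens) for antiproliferative activity, read by fluorescence and resazurin assay, with a stated time of 48 h; on this read-out higher numbers stand for weaker inhibition and lower numbers for stronger inhibition. Compound 1 `Cc1noc(NS(=O)(=O)c2ccc(NC(=O)c3cc4cc([N+](=O)[O-])ccc4oc3=O)cc2)c1C` gives 11900 nM. Compound 2 `Cc1noc(NS(=O)(=O)c2ccc(NC(=O)c3cc4cc(Br)ccc4oc3=O)cc2)c1C` differs from compound 1 in one place, (bromo in place of nitro on an aromatic carbon), and compound 2 gives 28700 nM, so the step is a 2.4-fold higher number from compound 1 to compound 2 (0.38 log units; beyond the scatter). Compound 3 `O=C(N/N=C/c1cccnc1)c1cc2cc([N+](=O)[O-])ccc2oc1=O` carries the same nitro group on the same kind of aromatic carbon but is built up differently on the other side of the shared core; the difference between the two cores is not broken down here. Going by the values given here, compound 3 gives 11800 nM, a number that lies within the usual scatter of the one for compound 1, so the two cannot be placed in order.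

Compound 4 `O=C(N/N=C/c1cccnc1)c1cc2cc(Br)ccc2oc1=O` has not yet been measured. It stands to compound 3 as compound 2 stands to compound 1: bromo in place of nitro on an aromatic carbon. The description of the place is the same word for word in both pairs, so this is the same change, occurring twice among these four compounds. Among the compounds with values here, its one measured instance is a 2.4-fold higher number from compound 1 to compound 2 (0.38 log units; beyond the scatter). The step from compound 3 to compound 4 is therefore expected to be a 2.4-fold higher number from compound 3 to compound 4 (0.38 log units; beyond the scatter), because the same change in the other pair gave a 2.4-fold higher number from compound 1 to compound 2 (0.38 log units; beyond the scatter). The estimate for compound 4 is 28000 nM, expected to fall between 12000 nM and 70000 nM.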

Compound 4, half-maximal inhibitory concentration: 8350 nM
Compound 4: middle estimate off by 3.4-fold (0.53 log units), on the high side; measured number below the stated range.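

In this assay, bromo in place of nitro on an aromatic carbon gives a 1.4-fold lower number from compound 3 to compound 4 (0.15 log units; within the scatter), which means that on this core the swap produces no difference that can be told apart from the ordinary spread of repeated measurements. Set beside the earlier pair, the same swap did not behave alike on the two cores: the same change on two cores in this assay, a 2.4-fold higher number (0.38 log units; beyond the scatter) from compound 1 to compound 2 and a 1.4-fold lower number (0.15 log units; within the scatter) from compound 3 to compound 4, 3.4-fold (0.53 log units) apart, beyond the scatter of two such steps. This shows that one measured step for this change was not a safe guide to its size or direction on the core of compound 3, but it does not show why the two cores differ, and two pairs give no rule for how the change would behave on any further core.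

Only nitro and bromo appear at this place, which leaves open how an amine or a carboxylic acid on the same aromatic carbon would read on either core. Also open is which part of the structure built onto the shared core decides the size of the step, as compound 1 and compound 3 differ in that whole stretch and no compound shown changes it piece by piece.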